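The compounds below may be only part of what the source reports. "The series", "measured", "known", "first", "only" and "open" are said of these compounds alone.

In a functional assay on K562 cells (Homo sapiens) for antiproliferative activity, read by MTT assay (a lower number here means a stronger inhibitor, a higher number a weaker inhibitor), two compounds have been measured so far

Compound 1 `O=C(CCCCCNC(=S)N/N=C(\c1ccccc1)c1ccccn1)NO` gives 2140 nM
Compound 2 `Cc1ccc(/C(=N/NC(=S)NCCCCCC(=O)NO)c2ccccc2)cc1` gives 4340 nM

Compound 2 stands at the higher of these two numbers, with 4340 nM, which makes it the weaker inhibitor of the pair. For the measured compounds named here, the only measured step is a 2.0-fold higher number from compound 1 to compound 2 (0.31 log units; beyond the scatter), a modest move made on the carbon with a double bond to nitrogen.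

Compound 3 `O=C(CCCCCNC(=S)N/N=C(\c1ccccc1)c1cccc([N+](=O)[O-])c1)NO` has not been measured and changes that same place again, with 3-nitrophenyl in place of 4-methylphenyl on a carbon with a double bond to nitrogen. Going by the values given here, no measured compound carries the 3-nitrophenyl group, so the evidence is thin. Among the compounds with values here, the single step shows only that one swap at this place moved the number modestly. A step of about that size or smaller is therefore expected in this assay, leaning slightly towards a lower number and perhaps not beyond the scatter, since compound 2 holds the higher value of only two. The estimated step is a 1.4-fold lower number from compound 2 to compound 3 (0.13 log units; within the scatter). For compound 3 the expected value is 3200 nM, with an estimated range from 1300 nM to 8000 nM.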

Compound 3, half-maximal inhibitory concentration: 1630 nM
Beside the measured number, compound 3's estimate is 2.0-fold (0.29 log units) above it; low and high end bracket the measured number.
By their numbers in this assay, from the lowest: compounds 3 and 1 (each within the scatter of the next); then compound 2.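

In this assay, the place on the carbon with a double bond to nitrogen now shows a second swap, and 3-nitrophenyl in place of 4-methylphenyl gives a 2.7-fold lower number from compound 2 to compound 3 (0.43 log units; beyond the scatter), so the earlier rise at this place was not a lone move, and the number can also come back down. For the compounds shown here, replacing pyridin-2-yl with 3-nitrophenyl gives a 1.3-fold lower number from compound 1 to compound 3 (0.12 log units; within the scatter), so these two different groups cannot be told apart here, and compound 2, with 4-methylphenyl, is the one compound of the three whose steps to both others are beyond the scatter. Nothing available on these compounds accounts for this difference among the three groups.

The compounds leave open whether an amine or a carboxylic acid on the aromatic ring at this place would keep the number level with compound 1 and compound 3 or move it towards compound 2. They also leave open whether a longer chain in the shared core would shift all three compounds alike or change the differences among them.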